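The source may report more compounds than this note shows. Statements on the series, on what has been measured and on what is new or still open speak of the compounds shown alone.

Working notes on the series. Compound 1 `O=C(Cc1cccnc1)c1cc2ccccc2[nH]1` stands second highest of the three numbers in an assay on isolated protein for inhibition of Indoleamine 2,3-dioxygenase 1 (Homo sapiens), read by spectrophotometry (a lower number here means a stronger inhibitor, a higher number a weaker inhibitor), at 65000 nM. Compound 3 `COc1cccc2[nH]c(C(=O)Cc3cccnc3)cc12` gives 58000 nM in this assay, and the step of a 1.1-fold lower number from compound 1 to compound 3 (0.05 log units; within the scatter) is therefore not a change. Compound 2 `CC(C(=O)c1cc2ccccc2[nH]1)c1cccnc1` gives 141000 nM in this assay; the step of a 2.2-fold higher number from compound 1 to compound 2 (0.34 log units; beyond the scatter) is the only move beyond the scatter so far.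

Compound 4 `Cc1ccc2[nH]c(C(=O)Cc3cccnc3)cc2c1` is not yet measured. It differs from compound 1 by methyl in place of hydrogen on an aromatic carbon. The closer precedent is the aromatic-carbon change in a 1.1-fold lower number from compound 1 to compound 3 (0.05 log units; within the scatter), which stayed within the scatter; the chain-carbon change in a 2.2-fold higher number from compound 1 to compound 2 (0.34 log units; beyond the scatter) sits in another place. No step beyond the scatter is expected in this assay.

Compound 4 is estimated at 60000 nM in this assay, between 30000 nM and 120000 nM, the expected step being a 1.1-fold lower number from compound 1 to compound 4 (0.03 log units; within the scatter).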

Compound 4, half-maximal inhibitory concentration: 87000 nM
Compound 4: the middle estimate sits 1.5-fold (0.16 log units) below what was measured; measured number inside the range.
By their numbers in this assay, from the lowest: compounds 3, 1, 4 and 2 (each within the scatter of the next, the first and the last beyond it).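

Methyl in place of hydrogen on this aromatic carbon, meta to a fused ring and para to a fused ring, gives a 1.3-fold higher number from compound 1 to compound 4 (0.13 log units; within the scatter) and so shows no real change in this assay at this position. A small carbon group is therefore tolerated here, although this single step cannot show a trend. No available evidence accounts for the size of this step.

Going by these compounds, whether a carboxylic acid, an amine or a longer chain at this same carbon would move the number beyond the scatter remains open. Also open, on these data alone, is whether any change on this ring can bring the number clearly below that of compound 1.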